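The source may hold more compounds than are shown below. What is called first, only, known or untested is meant among the compounds shown, and "the series" means these compounds.

Measured compounds in an in vitro assay on CHO-CREluc cells for displacement of a labelled ligand from growth hormone secretagogue receptor type 1 (Homo sapiens), read by scintillation counting, with a stated time of 1 h; a higher number here means a weaker inhibitor, a lower number a stronger inhibitor:
- compound 1 `CCN1CCC(CC(=O)NC2(c3ccc(Cl)c(Cl)c3)C(=O)Nc3cc(Cl)cc(Cl)c32)CC1`: 3 nM
- compound 2 `CCN1CCN(CC(=O)NC2(c3ccc(Cl)cc3)C(=O)Nc3cc(Cl)c(C)cc32)CC1`: 286 nM
- compound 3 `CN1CCN(CC(=O)NC2(c3ccc(Cl)cc3)C(=O)Nc3cc(Cl)cc(Cl)c32)CC1`: 44 nM

Compound 1 has the lowest number of the three; its nearest neighbour is compound 3, whose number is higher and beyond the scatter, and compound 2 lies further off still. For the measured compounds named here, compounds 2 and 3 both carry a piperazinyl group on the chain, but each also differs from compound 1 elsewhere, so no single step between measured compounds isolates the chain group.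

Compound 4 `CCN1CCN(CC(=O)NC2(c3ccc(Cl)c(Cl)c3)C(=O)Nc3cc(Cl)cc(Cl)c32)CC1` is the direct test of that group on the core of compound 1: 4-ethylpiperazin-1-yl in place of 1-ethylpiperidin-4-yl on a saturated chain carbon bound to a carbonyl carbon. With the rest of compound 1 kept, the expectation rests on the direction shown by compounds 2 and 3, whose numbers in this assay lie above that of compound 1. The step from compound 1 to compound 4 is expected to go toward a higher number, of moderate size, estimated at a 6.7-fold higher number from compound 1 to compound 4 (0.82 log units; beyond the scatter). Compound 4 is expected to give about 20 nM, within 5 nM to 80 nM, in this assay.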

Compound 4, inhibition constant: 8 nM
Compound 4: middle estimate off by 2.5-fold (0.40 log units), on the high side; measured number inside the range.
By their numbers in this assay, from the lowest: compound 1; then compound 4; then compound 3; then compound 2.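

In this assay, for the compounds shown here, this is the first step that isolates the chain group: 4-ethylpiperazin-1-yl in place of 1-ethylpiperidin-4-yl on a saturated chain carbon bound to a carbonyl carbon gives a 2.7-fold higher number from compound 1 to compound 4 (0.43 log units; beyond the scatter). The exchange leaves the heavy-atom count unchanged and replaces one ring carbon with nitrogen, so on the core of compound 1 this position accepts the second ring hetero atom with a modest rise in the number. No available measurement accounts for the size or direction of this step.

Whether the step keeps its size on other cores remains open, as this is the only single-place pair shown. Also open, from the compounds shown here alone, is how this position responds to other groups, such as morpholin-4-yl or an open-chain diethylamino group.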